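A few compounds are considered here, and "the series" means these few. Any claim that something is new, unique, unknown or untested is made for them only; others in the source may bear on it.

Measured so far:

Compound 1 `CSc1ccc(CNc2nc(SC)nc3ncccc23)cc1` gives 1140 nM in an ADME assay on 184B5 cells (Homo sapiens) for cytotoxicity, read by MTT assay, with a stated time of 72 h; on this read-out lower numbers stand for stronger inhibition of growth and higher numbers for weaker inhibition of growth.
Compound 2 `[SeH]c1nc(NCc2ccccc2)c2cccnc2n1` gives 9130 nM in this assay.
Compound 3 `CSc1nc(NCCCc2ccccc2)c2ccccc2n1` sits at a limit of this assay, > 100000 nM; this is a limit of the measurement and not a number.

Among the two compounds with a number, compound 1 stands lowest, and the nearest number, that of compound 2, lies beyond the usual scatter; one further value, that of compound 3, is only a limit (the limit of > 100000 nM in this assay, at which 1 of the 3 values shown sits).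

Compound 4 `COc1ccc(CNc2nc(SC)nc3ncccc23)cc1` differs from compound 1 in one place: methoxy in place of methylsulfanyl on an aromatic carbon. Methoxy and methylsulfanyl are both small groups without hydrogen-bond donors, so the expectation is a step of modest size, if any, in the direction of a somewhat higher number. The estimate for compound 4 in this assay is 2000 nM, with a range from 700 nM to 6000 nM. The step this estimate implies is a 1.8-fold higher number from compound 1 to compound 4 (0.24 log units; within the scatter), which is expected to stay close to the scatter of repeated measurements.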

Compound 4, concentration for total growth inhibition: 69800 nM
For compound 4 the middle estimate is 35-fold (1.54 log units) below the measured one; measured number outside the range, above it.
By their numbers in this assay, from the lowest: compound 1; then compound 2; then compound 4. At a limit, above all of these: compound 3.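

Exchanging methylsulfanyl for methoxy on an aromatic carbon, para to a large group, gives in this assay a 61-fold higher number from compound 1 to compound 4 (1.79 log units; beyond the scatter). The two groups have the same counts of heavy atoms, hydrogen-bond donors and hydrogen-bond acceptors, so this place responds strongly to a change that those counts do not capture, with sulfur replaced by oxygen as the only difference in the atoms. Compound 3 alone sits at a limit of the assay, which is not a number, while compound 4 still has a measured value that can be compared: the limit of > 100000 nM in this assay, at which 1 of the 4 values shown sits.

Going by these compounds, whether an amine, a chlorine atom or a longer chain such as ethylsulfanyl at this place would stay close to compound 1 or move towards compound 4 remains open. Also open, on these data alone, is whether the same exchange would have a step of similar size on a different core.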